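This account rests on a few compounds, and the source may have more. Where it says the series, first, only, none or still open, it means among the compounds named here.

In a functional assay on G-361 cells (Homo sapiens) for inhibition, with a stated time of 72 h (a lower number here means a stronger inhibitor, a higher number a weaker inhibitor), compound 1 `NC1CCC(Nc2nc(NCc3ccc(-c4ccccc4)cc3)c3ncn(C4CCCC4)c3n2)CC1` gives 1020 nM, and compound 2 `NC1CCC(Nc2nc(NCc3ccc(-c4cccc(F)c4)cc3)c3ncn(C4CCCC4)c3n2)CC1` gives 815 nM. These two values cannot be told apart: the measured step is a 1.3-fold lower number from compound 1 to compound 2 (0.10 log units; within the scatter), with fluoro in place of hydrogen on an aromatic carbon.

Compound 3 `NC1CCC(Nc2nc(NCc3ccc(-c4ccco4)cc3)c3ncn(C4CCCC4)c3n2)CC1` changes the group carried on the six-membered aromatic ring: furan-2-yl in place of 3-fluorophenyl on an aromatic carbon. This puts furan-2-yl in place of 3-fluorophenyl, para to a large group. For the measured compounds named here, the single measured step is only a loose guide, since it keeps the six-membered aromatic ring and no measured compound carries furan-2-yl. With so little evidence, no shift beyond the scatter is expected in this assay, though the uncertainty is wide. The expected step is a 1.1-fold higher number from compound 2 to compound 3 (0.04 log units; within the scatter). For compound 3 the estimated value is 900 nM, with an expected range of 400 nM to 2000 nM.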

Compound 3, half-maximal inhibitory concentration: 164 nM
Estimate against measurement, compound 3: 5.5-fold (0.74 log units) above, and the stated range ends above it.
By their numbers in this assay, from the lowest: compound 3; then compounds 2 and 1 (each within the scatter of the next).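

In this assay the place on the six-membered aromatic ring of carbon only, para to a large group, proves sensitive to the ring it carries: furan-2-yl in place of 3-fluorophenyl gives a 5.0-fold lower number from compound 2 to compound 3 (0.70 log units; beyond the scatter) and furan-2-yl in place of phenyl gives a 6.2-fold lower number from compound 1 to compound 3 (0.79 log units; beyond the scatter) in the same direction. The earlier fluoro exchange on the phenyl ring gave only a 1.3-fold lower number from compound 1 to compound 2 (0.10 log units; within the scatter) and so gave no sign of this sensitivity. Nothing measured independently of this assay accounts for the gain.

Ring size, the ring oxygen and the added hydrogen-bond acceptor all change together in these steps, so their contributions cannot be separated. Furan-3-yl, thiophen-2-yl and pyridin-3-yl at this place would help to separate them, and a substituted furan-2-yl would show whether the entering ring tolerates further change.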